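The source may hold more compounds than are shown below. What is called first, only, known or untested is meant among the compounds shown, and "the series" means these compounds.

In a functional assay on HeLa cells (Homo sapiens) for antiproliferative activity, read by MTT assay, with a stated time of 48 h (on this read-out higher numbers stand for weaker inhibition and lower numbers for stronger inhibition), three compounds have numbers or limits so far. Compound 1 (`COc1cc(CNC(=O)CCCCCCC(C)C)ccc1OCCCCOc1ccc(C(N)=S)cc1`) gives 40700 nM. Compound 3 (`COc1cc(CNC(=O)CCCCCCC(C)C)ccc1OCCCCCOc1ccc(C(N)=S)cc1`) gives > 50000 nM, which is a limit and not a number. Compound 2 (`COc1cc(CNC(=O)CCCC/C=C/C(C)C)ccc1OCCCCCOc1ccc(-c2cc(=S)ss2)cc1`) gives > 50000 nM, which is also a limit. As far as these compounds go, compound 3 therefore stands at the limit of > 50000 nM in this assay, at which 2 of the 3 values shown sit, and its true value remains unknown.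

Compound 4 (`COc1cc(CNC(=O)CCCCCCC(C)C)ccc1OCCCCCOc1ccc(-c2cc(=S)ss2)cc1`) keeps the rest of compound 3 and exchanges one group: a group of 6 heavy atoms (3 carbon, 3 sulfur; one five-membered aromatic ring with 2 hetero atoms) in place of a group of 3 heavy atoms (1 carbon, 1 nitrogen, 1 sulfur; no ring), on an aromatic carbon. The new group sits on an aromatic carbon of a six-membered aromatic ring of carbon only, para to a large group.

Two results bear on this change. The measured step of an at least 1.2-fold higher number from compound 1 to compound 3 (0.08 log units; that floor lies within the scatter) is a change in the chain rather than in the exchanged group, and it lies within the scatter, so it offers little guidance here. Compound 2 already carries a five-membered aromatic ring with 2 hetero atoms, and its result is the limit > 50000 nM. Neither result points to a gain, so no step beyond the scatter is expected in this assay, and another limit is the likeliest report.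

The expected step is a number no higher from compound 3 to compound 4 (the limit leaves the size open). Compound 4 is estimated at 50000 nM, with an expected range from 20000 nM to 100000 nM.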

Compound 4, half-maximal inhibitory concentration: > 50000 nM
Compound 4: only a limit was reported; the forecaster's own chance of this, stated with the estimate: 70%; the middle value sits exactly at the limit.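

Compound 4 gives > 50000 nM as its result, which is a limit and not a number. No step can be read from compound 2 or compound 3 to compound 4, as all three results are only limits: the limit of > 50000 nM in this assay, at which 3 of the 4 values shown sit. As far as these compounds go, the true values of these three compounds stay open, and so does whether either exchange changes inhibition at all.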